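Moving the Fluorine Around the Phenyl Ring

The compounds below may be only part of what the source reports. "The series", "measured", "known", "first", "only" and "open" are said of these compounds alone.

Of the compounds shown here, three built on one shared core have been measured in an assay on CHO cells for displacement of a labelled ligand from 5-hydroxytryptamine receptor 1D (Homo sapiens); a lower number here means a stronger inhibitor, a higher number a weaker inhibitor. Compound 1 `FC1(CCc2ccccc2)CCN(CCCc2c[nH]c3ccc(-n4cnnc4)cc23)CC1` carries a plain phenyl ring and gives 2 nM. Compound 2 `Fc1ccccc1CCC1(F)CCN(CCCc2c[nH]c3ccc(-n4cnnc4)cc23)CC1` gives 0.8 nM, and compound 3 `Fc1cccc(CCC2(F)CCN(CCCc3c[nH]c4ccc(-n5cnnc5)cc34)CC2)c1` gives 0.7 nM. Adding a fluorine to the ring lowered the number in both cases: a 2.5-fold lower number from compound 1 to compound 2 (0.40 log units; beyond the scatter) and a 2.9-fold lower number from compound 1 to compound 3 (0.46 log units; beyond the scatter). Between the two fluorinated compounds the difference is small, a 1.1-fold lower number from compound 2 to compound 3 (0.06 log units; within the scatter), so compound 3 holds the lowest number of the three but is separated beyond the scatter only from compound 1, not from compound 2.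

Compound 4 `Fc1ccc(CCC2(F)CCN(CCCc3c[nH]c4ccc(-n5cnnc5)cc34)CC2)cc1` has not yet been measured. It differs from compound 3 in one respect: 4-fluorophenyl in place of 3-fluorophenyl on a saturated chain carbon, two bonds along the chain from a saturated ring carbon. The step that bears most directly on this change is the earlier exchange of one fluorophenyl for another, and that step lay within the scatter. The two steps from compound 1 show that fluorine on the ring matters, yet not where it sits, so far as these three compounds reveal. Compound 4 is therefore expected to show a step of a 1.1-fold higher number from compound 3 to compound 4 (0.06 log units; within the scatter) that stays within the scatter, because a 1.1-fold lower number from compound 2 to compound 3 (0.06 log units; within the scatter) was itself within the scatter. Compound 4 is estimated at 0.8 nM, with a range from 0.4 nM to 1.6 nM.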

Compound 4, half-maximal inhibitory concentration: 1 nM
Compound 4: middle estimate off by 1.3-fold (0.10 log units), on the low side; the range from low to high includes it.
By their numbers in this assay, from the lowest: compounds 3, 2, 4 and 1 (each within the scatter of the next, the first and the last beyond it).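

In this assay, changing 3-fluorophenyl to 4-fluorophenyl gives a step within the scatter (a 1.4-fold higher number from compound 3 to compound 4 (0.15 log units; within the scatter)), and so does changing 2-fluorophenyl to 4-fluorophenyl (a 1.3-fold higher number from compound 2 to compound 4 (0.10 log units; within the scatter)), so all three fluorophenyl groups at this place, on a saturated chain carbon, now lie within the scatter of one another. The new compound also qualifies the earlier picture: adding fluorine to the plain phenyl ring gave steps beyond the scatter for compound 2 and compound 3, but the step to the 4-fluorophenyl group stays within it (a 2.0-fold lower number from compound 1 to compound 4 (0.30 log units; within the scatter)), so compound 4 goes against that pattern. Nothing available explains this difference among the steps from compound 1.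

The compounds shown leave open whether a larger change on the phenyl ring, such as a chloro or methoxy group in place of the fluorine, would separate from the fluorophenyl compounds beyond the scatter. They also leave open what a longer chain than the 2-(4-fluorophenyl)ethyl group would do to the number in this assay.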